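The source may hold more compounds than are shown below. What is called first, only, known or untested is meant among the compounds shown, and "the series" means these compounds.

Compound 1, `Cc1cc(S(=O)(=O)/N=C(\N)n2nccc2-c2ccccc2)c(SCc2ccccc2Cl)cc1Cl`, gives 20000 nM in an ADME assay on HaCaT cells (Homo sapiens) for cytotoxicity, read by MTT assay, with a stated time of 72 h; on this read-out higher numbers stand for weaker inhibition and lower numbers for stronger inhibition.
Compound 2, `Cc1cccc(CSc2cc(Cl)c(C)cc2S(=O)(=O)/N=C(\N)n2nccc2-c2ccccc2)c1`, gives 10000 nM.
Compound 3, `Cc1cc(-c2ccccc2)n(/C(N)=N/S(=O)(=O)c2cc(C)c(Cl)cc2SCc2ccc(C(F)(F)F)cc2)n1`, gives 18000 nM.

These three compounds share one core and differ only in the aromatic group attached to a saturated chain carbon bound to a sulfur. Compound 3 sits among the other two: its gap to compound 1 and its gap to compound 2 both lie within the usual scatter of repeated measurements, so no ordering among them can be claimed.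

Compound 4, `Cc1cc(-c2ccccc2)n(/C(N)=N/S(=O)(=O)c2cc(C)c(Cl)cc2SCc2cccc3ccccc23)n1`, carries the change (naphthalen-1-yl in place of 4-(trifluoromethyl)phenyl on a saturated chain carbon bound to a sulfur). Going by the values given here, the only measured step at the same place is a 2.0-fold lower number from compound 1 to compound 2 (0.30 log units; within the scatter), which swapped one aromatic group for another and stayed within the scatter. On that basis no step beyond the scatter is expected here either, so the estimated change is no change at the digits printed from compound 3 to compound 4 (within the scatter). Compound 4 is therefore expected to give about 18000 nM in this assay, with a likely range from 7000 nM to 40000 nM.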

Compound 4, half-maximal inhibitory concentration: 12000 nM
The estimate for compound 4 lay 1.5-fold (0.18 log units) above the measured number, and the stated range covers the measured number.
By their numbers in this assay, from the lowest: compounds 2, 4, 3 and 1 (each within the scatter of the next).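

In this assay, going from a single aromatic ring carrying trifluoromethyl to the two fused rings of naphthalen-1-yl gives a 1.5-fold lower number from compound 3 to compound 4 (0.18 log units; within the scatter). This is a second step at this position, on a saturated chain carbon bound to a sulfur, and like the first it stays within the scatter, even though the number of aromatic rings now changes while the heavy-atom count stays the same. No supporting measurement bears on this result.

Going by these compounds alone, all the groups at this position so far are aromatic rings of carbon only, so what an amine, a carboxylic acid or a plain alkyl chain would do here remains open. Going by these compounds, whether any group at this position can move the number beyond the scatter also remains open.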